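A few compounds are considered here, and "the series" means these few. Any claim that something is new, unique, unknown or untested is made for them only; others in the source may bear on it.

Working notes on a small set built on the shared core of compound 1 `O=C1c2ccccc2C(=O)N1CCOC(=S)N(C(=O)c1cccc([N+](=O)[O-])c1)c1ccc(Cl)cc1`. For the measured compounds named here, in an ADME assay on MT4 cells (Homo sapiens) for cytotoxicity, read by MTT assay (on this read-out higher numbers stand for lower toxicity in this test and lower numbers for higher toxicity in this test), compound 1 gives 18000 nM, the only plain number in the set. Compound 2 `O=C1c2ccccc2C(=O)N1CCOC(=S)N(C(=O)c1cccnc1Cl)c1ccc(Br)cc1` is reported in this assay as a limit, > 100000 nM, not as a number. That reading is the limit of > 100000 nM in this assay, at which 1 of the 2 values shown sits. Going by the values given here, no step between measured compounds is available, so compound 1 and compound 2 are compared only by what their two readings show: a number against a limit.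

Compound 3 `O=C1c2ccccc2C(=O)N1CCOC(=S)N(C(=O)c1cc(Cl)cc(Cl)c1)c1ccc(Cl)cc1` is not yet measured in this assay. It differs from compound 1 in one place: 3,5-dichlorophenyl in place of 3-nitrophenyl on a carbonyl carbon. Among the compounds with values here, with no measured step to lean on, the change is expected to shift the read-out little, probably within the usual scatter, with a slight lean toward lower numbers; the expected step is a 1.5-fold lower number from compound 1 to compound 3 (0.18 log units; within the scatter). For compound 3 the estimate is 12000 nM, within 3000 nM to 50000 nM.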

Compound 3, half-maximal cytotoxic concentration: 32000 nM
For compound 3 the middle estimate is 2.7-fold (0.43 log units) below the measured one, and the stated range covers the measured number.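

For the compounds shown here, replacing 3-nitrophenyl with 3,5-dichlorophenyl on the carbonyl carbon gives the first readable step, in this assay: a 1.8-fold higher number from compound 1 to compound 3 (0.25 log units; within the scatter). At this position, a ring with hydrogen-bond acceptors and a ring with none therefore give readings that cannot be told apart, so this one swap leaves the cytotoxicity reading within the usual scatter. Nothing on hand bears on why this step is so small.

Compound 2 is reported only as a limit and differs from the others in more than one place, so it does not show how far this position can move the reading. Still open, on these data alone, is whether a carboxylic acid or an amine on this ring, or a longer alkyl chain in place of the ring, would move the reading beyond the scatter.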